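Swapping Pyridin-4-yl for Thiophen-2-yl in Compound 1

The source may report more compounds than this note shows. Statements on the series, on what has been measured and on what is new or still open speak of the compounds shown alone.

Among the measured compounds shown here, in a functional assay on HT-29 cells (Homo sapiens) for inhibition, with a stated time of 72 h (a lower number here means a stronger inhibitor, a higher number a weaker inhibitor), compound 1 (`COc1ccc(S(=O)(=O)N2CCc3cccc(-c4ccncc4)c32)cc1`) gives 87.5 nM and sits at the low end of the three numbers measured so far. Compound 2 (`COc1ccc(S(=O)(=O)n2ccc3cccc(-c4ccc(C#N)cc4)c32)cc1`) gives 164 nM and lies within the scatter of compound 1. Compound 3 (`COc1ccc(S(=O)(=O)n2ccc3cccc(-c4ccc(F)cc4)c32)cc1`) gives 196 nM and lies beyond the scatter of compound 1, on the higher side.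

Compound 4 (`COc1ccc(S(=O)(=O)N2CCc3cccc(-c4cccs4)c32)cc1`) keeps the core of compound 1 but carries thiophen-2-yl in place of pyridin-4-yl on an aromatic carbon. For the measured compounds named here, no measured pair makes this exchange of one aromatic ring for another. Going by the values given here, the closest evidence is a smaller change elsewhere, fluoro in place of cyano on an aromatic carbon, which gives a 1.2-fold higher number from compound 2 to compound 3 (0.08 log units; within the scatter) and shows only that this one exchange left the number within the scatter. That is weak support, but it points to a modest effect rather than a large one. With compound 1 at the low end of the measured numbers, a small move toward a higher number seems the likelier direction. The expected step in this assay is a 1.6-fold higher number from compound 1 to compound 4 (0.20 log units; within the scatter) and so a modest one. For compound 4 the estimate is 140 nM with an expected range of 50 nM to 400 nM.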

Compound 4, half-maximal inhibitory concentration: 200 nM
Beside the measured number, compound 4's estimate is 1.4-fold (0.15 log units) below it; the measured number falls inside the stated range.
By their numbers in this assay, from the lowest: compounds 1, 2, 3 and 4 (each within the scatter of the next, the first and the last beyond it).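

In this assay, thiophen-2-yl in place of pyridin-4-yl gives a 2.3-fold higher number from compound 1 to compound 4 (0.36 log units; beyond the scatter), so this aromatic carbon is a place where exchanging one aromatic ring for another can move the number beyond the usual scatter. Among the compounds shown here, the only earlier step, a swap of cyano for fluoro on the outer ring of a different core, stayed within the scatter. The two rings exchanged here have the same counts of hydrogen-bond donors and acceptors and no net charge, so those counts do not separate them, while ring size and the hetero atom do differ; no measurement here shows what lies behind the step.

Only one ring exchange on this core is shown, so it remains open whether ring size or the change from nitrogen to sulfur matters more, and rings such as furan-2-yl or pyridin-3-yl at this place could help to separate the two. Also open, as far as these compounds go, is how a non-aromatic group here, such as an amine or a carboxylic acid, would behave, and whether the same exchange on the core of compound 2 would give a step of similar size.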